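Adding a sulfamoyl group to a dihydroxy pyrazole

The source may hold more compounds than are shown below. What is called first, only, known or untested is meant among the compounds shown, and "the series" means these compounds.

Compound 1 `COc1ccc(OC)c(-c2cc(-c3ccccc3)nn2-c2ccc(S(N)(=O)=O)cc2)c1`: 27500 nM
Compound 2 `Oc1ccc(O)c(-c2cc(-c3ccccc3)nn2-c2ccccc2)c1`: 77400 nM
Compound 3 `Oc1ccc(O)c(-c2cc(-c3ccc(Cl)cc3)nn2-c2ccccc2)c1`: 16800 nM

In a functional assay on cells (Cancer cell lines, Homo sapiens) for cytotoxicity, read by sulforhodamine B assay, with a stated time of 48 h (on this read-out lower numbers stand for stronger inhibition of growth and higher numbers for weaker inhibition of growth), compound 2 gives 77400 nM, the highest of the three numbers. Its nearest neighbour is compound 1, which in this assay gives 27500 nM; the furthest is compound 3, which gives 16800 nM. Among the compounds with values here, compound 1 differs from compound 2 in more than one place, so their two values show only that the compound carrying the sulfamoyl group and the methoxy groups sits lower.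

Compound 4 `NS(=O)(=O)c1ccc(-n2nc(-c3ccccc3)cc2-c2cc(O)ccc2O)cc1` is obtained from compound 2 by the change (sulfamoyl in place of hydrogen on an aromatic carbon), placed on an aromatic carbon of a six-membered aromatic ring of carbon only, para to a large group. Within the data shown here, no measured step touches this change on its own. Among the measured compounds shown here, the only single step available, a 4.6-fold lower number from compound 2 to compound 3 (0.66 log units; beyond the scatter), concerns a different ring and a different group, and shows that a single substituent on one of the aromatic rings of this core can move the number by a modest amount.

On that basis compound 4 is expected to sit somewhat lower than compound 2, a step of about a 2.6-fold lower number from compound 2 to compound 4 (0.41 log units; beyond the scatter). Compound 4 is therefore estimated at 30000 nM, within a range from 10000 nM to 90000 nM.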

Compound 4, concentration for total growth inhibition: 100000 nM
Compound 4: the middle estimate sits 3.3-fold (0.52 log units) below what was measured; measured number outside the range, above it.
By their numbers in this assay, from the lowest: compounds 3 and 1 (each within the scatter of the next); then compounds 2 and 4 (each within the scatter of the next).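

In this assay, sulfamoyl in place of hydrogen, on an aromatic carbon para to a large group, gives a 1.3-fold higher number from compound 2 to compound 4 (0.11 log units; within the scatter), so on this core the two compounds cannot be told apart at this position, and a substituent on this ring need not shift the number as the chloro group did on the other ring. With the sulfamoyl group present in both compounds, 2,5-dihydroxyphenyl in place of 2,5-dimethoxyphenyl gives a 3.6-fold higher number from compound 1 to compound 4 (0.56 log units; beyond the scatter), a modest step beyond the scatter, which separates this change from the sulfamoyl change in a way that the two-place difference between compound 1 and compound 2 could not. No available measurement explains either step.

Going by these compounds, it remains open what an amine or a carboxylic acid would give at this same place, and whether a sulfamoyl group counts for as little when 2,5-dimethoxyphenyl stands in place of 2,5-dihydroxyphenyl. Also open, on these data alone, is whether the chloro group of compound 3 would keep its step in a compound that also carries the sulfamoyl group.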